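This account rests on a few compounds, and the source may have more. Where it says the series, first, only, none or still open, it means among the compounds named here.

Measured so far in an ADME assay on microsomes (Mus musculus) for metabolic stability; a higher number here means faster removal of the compound, a lower number slower removal:
- compound 1 `Cc1cc(C(F)(F)F)c2cccc(OCc3c(Cl)ccc(S(=O)(=O)N4CCC[C@H]4C(=O)O)c3Cl)c2n1`: 13.3 mL/min/kg
- compound 2 `Cc1cc(C(F)(F)F)c2cccc(OCc3c(Cl)ccc(S(=O)(=O)N4CCC[C@H]4CO)c3Cl)c2n1`: 1630 mL/min/kg
- compound 3 `Cc1cc(C(F)(F)F)c2cccc(OCc3c(Cl)ccc(S(=O)(=O)N4CCCC4)c3Cl)c2n1`: 967 mL/min/kg

Compound 3, at 967 mL/min/kg, shares the high end of these numbers with compound 2, while compound 1 stands far apart at the low end. The next structure, compound 4 `Cc1cc(C(F)(F)F)c2cccc(OCc3c(Cl)ccc(S(=O)(=O)N4CCC(C#N)CC4)c3Cl)c2n1`, keeps the shared core and alters only the group on the sulfonyl sulfur, with 4-cyanopiperidin-1-yl in place of pyrrolidin-1-yl on a sulfonyl sulfur.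

Among the compounds with values here, no measured step covers this exact change, so the guidance is indirect. The two large steps, a 120-fold higher number from compound 1 to compound 2 (2.09 log units; beyond the scatter) and a 73-fold higher number from compound 1 to compound 3 (1.86 log units; beyond the scatter), both involve losing the carboxy group, which neither compound 3 nor compound 4 carries. The closer comparison is a 1.7-fold lower number from compound 2 to compound 3 (0.23 log units; within the scatter), a change on the saturated ring that stays without carboxy. On that basis, no step beyond the scatter is expected in this assay. Within the data shown here, no measured compound carries a nitrile or a six-membered ring of this kind, so the range is kept wide. The expected step is a 1.4-fold lower number from compound 3 to compound 4 (0.14 log units; within the scatter). For compound 4 the estimate is 700 mL/min/kg, with an expected range of 280 mL/min/kg to 1700 mL/min/kg.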

Compound 4, clearance: 1720 mL/min/kg
Estimate against measurement, compound 4: 2.5-fold (0.39 log units) below, and the stated range ends below it.
By their numbers in this assay, from the lowest: compound 1; then compounds 3, 2 and 4 (each within the scatter of the next).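

In this assay, replacing pyrrolidin-1-yl on the sulfonyl sulfur with 4-cyanopiperidin-1-yl, a six-membered ring that carries a nitrile, gives a 1.8-fold higher number from compound 3 to compound 4 (0.25 log units; within the scatter) and so leaves the number within the usual scatter. Set against the hydroxymethyl-bearing ring, the same group gives a 1.1-fold higher number from compound 2 to compound 4 (0.02 log units; within the scatter) and, with compound 2 and compound 3, compound 4 now makes a third structure without a carboxy group whose number lies at the high end, even with a different ring size and a nitrile in play. The 2-carboxypyrrolidin-1-yl group of compound 1 remains the only one that stands apart, with a 130-fold higher number from compound 1 to compound 4 (2.11 log units; beyond the scatter) and no measurement here that offers a reason for this gap.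

Compound 4 changes the ring size and adds the nitrile at once, which leaves the two changes unseparated, and a plain piperidin-1-yl group would be the comparison that parts them. Also open, as far as these compounds go, is whether the low number of compound 1 goes with a carboxylic acid on any ring at this sulfonyl sulfur, as in 4-carboxypiperidin-1-yl, or only with the acid on the pyrrolidine ring.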